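The compounds below may be only part of what the source reports. "The series", "measured", "known", "first", "only" and "open" are said of these compounds alone.

Among the measured compounds shown here, compound 1 `CC1CN(C(=O)c2ccc(-c3ccc(NC(=O)Nc4ccc(Cl)c(C(F)(F)F)c4)cc3)cc2)CC(C)O1` is one of two compounds measured in a functional assay on HepG2 cells (Homo sapiens) for inhibition, read by MTT assay, with a stated time of 120 h (a higher number here means a weaker inhibitor, a lower number a stronger inhibitor), where compound 1 gives 31100 nM. The other measured compound, compound 2 `CNC(=O)CCc1ccc(NC(=O)Nc2ccc(Cl)c(C(F)(F)F)c2)cc1`, gives 21000 nM in this assay. Compound 1 has the highest of the two numbers, but its nearest neighbour, compound 2, stands within the scatter of it, so the two values show no difference that can be called real. Compound 3 `CC1CN(C(=O)c2ccc(-c3ccc(NC(=O)Nc4cc(C(F)(F)F)ccc4Cl)cc3)cc2)CC(C)O1` has not yet been measured in this assay. It differs from compound 1 in one place: 2-chloro-5-(trifluoromethyl)phenyl in place of 4-chloro-3-(trifluoromethyl)phenyl on an amide-type nitrogen. The two compounds share every atom and differ only in how the chlorine and trifluoromethyl substituents are arranged on the phenyl ring that sits on that amide-type nitrogen. For the measured compounds named here, no measured pair in this set shows what such a rearrangement does to the number in this assay, so the step has to be guessed. The step from compound 1 to compound 3 is expected to be a 1.2-fold higher number from compound 1 to compound 3 (0.06 log units; within the scatter), that is, none that clearly exceeds the scatter. Compound 3 is therefore estimated to give 36000 nM in this assay, with a range from 12000 nM to 110000 nM.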

Compound 3, half-maximal inhibitory concentration: > 50000 nM
Compound 3: only a limit was reported; the forecaster's own chance of this, stated with the estimate: 15%; middle value at least 1.3-fold (0.14 log units) from the limit.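

In this assay compound 3 gives > 50000 nM, which is a limit of the assay and not a number. Among the compounds shown here, exchanging 4-chloro-3-(trifluoromethyl)phenyl for 2-chloro-5-(trifluoromethyl)phenyl on the amide-type nitrogen gives the first step that can be read at this place, an at least 1.6-fold higher number from compound 1 to compound 3 (0.20 log units; that floor lies within the scatter), so the rearrangement of the same atoms shows no sign of a lower number, while the size of any real difference stays unknown. The result for this change therefore rests on a reading that gives only a floor, and the pair cannot be placed further apart than that: the limit of > 50000 nM in this assay, at which 1 of the 3 values shown sits.

The compounds shown leave open whether another group on this phenyl ring, such as a nitrile or a methoxy group in place of the chlorine or the trifluoromethyl, would bring the number down in this assay, and whether the same rearrangement would give a similar step on the core of compound 2. Going by these compounds, it also remains open whether an amine or a carboxylic acid added to the shared core of compound 1 would move the number at all.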